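The source may report more compounds than this note shows. Statements on the series, on what has been measured and on what is new or still open speak of the compounds shown alone.

Among the compounds with values here, in a functional assay on HUVEC cells (Homo sapiens) for inhibition, with stated times of 2 h and 72 h (a higher number here means a weaker inhibitor, a lower number a stronger inhibitor), compound 3 (`COc1cc2nccc(Oc3ccc4c(NC(=O)c5cc(Cl)ccn5)nn(C)c4c3)c2cc1OC`) gives 27 nM, the lowest of the three numbers so far. Compound 1 (`COc1cc2nccc(Oc3ccc4c(NC(=O)c5cc(C(F)(F)F)cc(C(F)(F)F)c5)nn(C)c4c3)c2cc1OC`) gives 58 nM, and compound 2 (`COc1cc2nccc(Oc3ccc4c(NC(=O)Nc5ccc(C(F)(F)F)cc5Cl)nn(C)c4c3)c2cc1OC`) gives 1150 nM.

Compound 4 (`COc1cc2nccc(Oc3ccc4c(NC(=O)c5cccc(C)c5)nn(C)c4c3)c2cc1OC`) carries 3-methylphenyl in place of 4-chloropyridin-2-yl on a carbonyl carbon.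

Within the data shown here, the one measured step at this carbonyl carbon is a 43-fold lower number from compound 2 to compound 3 (1.63 log units; beyond the scatter). That step, large as it is, starts from a (2-chloro-4-(trifluoromethyl)phenyl)amino group, which neither compound 3 nor compound 4 has, so it bears only weakly on this change. The closer guide is compound 1 at 58 nM, which like compound 4 has an aromatic ring of carbon only on the carbonyl carbon. In this assay a small rise is therefore expected, far short of the large step above. The expected change is a 2.2-fold higher number from compound 3 to compound 4 (0.35 log units; beyond the scatter). For compound 4 the estimated value is 60 nM, with an expected range of 20 nM to 200 nM.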

Compound 4, half-maximal inhibitory concentration: 2 nM
The estimate for compound 4 lay 30-fold (1.48 log units) above the measured number; measured number below the stated range.
By their numbers in this assay, from the lowest: compound 4; then compound 3; then compound 1; then compound 2.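

Within the data shown here, on the carbonyl carbon, 3-methylphenyl in place of 4-chloropyridin-2-yl gives a 14-fold lower number from compound 3 to compound 4 (1.13 log units; beyond the scatter), so in this assay this position can still move the number far below the earlier compounds. Replacing (2-chloro-4-(trifluoromethyl)phenyl)amino with the same 3-methylphenyl gives a 580-fold lower number from compound 2 to compound 4 (2.76 log units; beyond the scatter), which widens the span seen at this carbonyl carbon. An aromatic ring of carbon only does not by itself secure the low number: compound 1 also carries such a ring there and gives 58 nM.

Nothing measured here explains the gain in compound 4. The compounds shown leave open whether the methyl of 3-methylphenyl is needed, and whether a longer chain, an amine or a carboxylic acid in its place would keep the number this low.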